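Methyl on the Aromatic Nitrogen, Carried to a Second Core

The compounds below may be only part of what the source reports. "The series", "measured", "known", "first", "only" and "open" are said of these compounds alone.

Compound 1 `O=C(N/N=C\c1cn(Cc2ccc(Cl)cc2)c2cc(F)ccc12)c1c[nH]c2ccccc12` is the reference point of this small set. In a functional assay on MDA-MB-231 cells (Homo sapiens) for cytotoxicity (on this read-out higher numbers stand for weaker inhibition and lower numbers for stronger inhibition), compound 1 gives 5300 nM. Compound 2 `Cn1cc(C(=O)N/N=C\c2cn(Cc3ccc(Cl)cc3)c3cc(F)ccc23)c2ccccc21` differs from compound 1 by methyl in place of hydrogen on an aromatic nitrogen. For compound 2 the result in this assay is a limit of the assay, > 100000 nM. The step of an at least 18-fold higher number from compound 1 to compound 2 (1.27 log units; beyond the scatter) therefore rests on (the limit of > 100000 nM in this assay, at which 1 of the 3 values shown sits), and its true size is not resolved beyond that bound. Compound 3 `COc1ccc(Cn2cc(/C=N\NC(=O)c3c[nH]c4ccccc34)c3ccc(F)cc32)cc1` carries a different core; it differs from compound 1 by methoxy in place of chloro on an aromatic carbon. In this assay, for the measured compounds named here, compound 3 gives 71200 nM, a step of a 13-fold higher number from compound 1 to compound 3 (1.13 log units; beyond the scatter), which makes compound 3 the weaker of the two numbers measured so far. Compound 4 `COc1ccc(Cn2cc(/C=N\NC(=O)c3cn(C)c4ccccc34)c3ccc(F)cc32)cc1`, not yet measured, differs from compound 3 by methyl in place of hydrogen on an aromatic nitrogen. This is the same change as that made from compound 1 to compound 2: the description of the place is identical word for word for both pairs, and only the surrounding core differs, as told above. Going by the values given here, from the one measured instance of this change, a large loss is expected. Compound 4 is estimated at 300000 nM, with a range from 100000 nM to 1500000 nM. The expected step is a 4.2-fold higher number from compound 3 to compound 4 (0.62 log units; beyond the scatter), resting on an at least 18-fold higher number from compound 1 to compound 2 (1.27 log units; beyond the scatter). The result for compound 4 is expected most likely to come back as a limit of the assay rather than a number.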

Compound 4, half-maximal inhibitory concentration: 17700 nM
For compound 4 the middle estimate is 17-fold (1.23 log units) above the measured one, outside the stated range (below it).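

In this assay, methyl in place of hydrogen on the aromatic nitrogen does not carry from one core to the other: a 4.0-fold lower number from compound 3 to compound 4 (0.60 log units; beyond the scatter) stands against the earlier loss on the core of compound 1, and the two steps differ in direction as well as size: the same change on two cores in this assay, an at least 18-fold higher number (1.27 log units; beyond the scatter) from compound 1 to compound 2 and a 4.0-fold lower number (0.60 log units; beyond the scatter) from compound 3 to compound 4, at least 75-fold (1.88 log units) apart, beyond the scatter of two such steps
Read the other way round the square, methoxy in place of chloro also depends on what sits on the aromatic nitrogen, with an at least 5.6-fold lower number from compound 2 to compound 4 (0.75 log units; beyond the scatter) set against the earlier step on the hydrogen-bearing compounds: the same change on two cores in this assay, a 13-fold higher number (1.13 log units; beyond the scatter) from compound 1 to compound 3 and an at least 5.6-fold lower number (0.75 log units; beyond the scatter) from compound 2 to compound 4, at least 75-fold (1.88 log units) apart, beyond the scatter of two such steps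
The value of compound 2, > 100000 nM, is a limit of the assay, so every step touching it is a bound, and with one instance on each core the set shows that this change failed to transfer here, but not why, nor how it would behave on any further core: the limit of > 100000 nM in this assay, at which 1 of the 4 values shown sits.

On these data alone, it remains open whether an ethyl group or a longer chain on the aromatic nitrogen would split between the two cores in the same way as methyl. Also open, as far as these compounds go, is what the methyl step does when bromo or a plain hydrogen takes the place of chloro and methoxy.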